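The source may report more compounds than this note shows. Statements on the series, on what has been measured and on what is new or still open speak of the compounds shown alone.

Measured so far in an assay on cells for agonist activity at ecdysone receptor (Bombyx mori), read by a luciferase reporter, with a stated time of 24 h; a higher number here means that more compound is needed for the effect, a lower number that less compound is needed:
compound 1 `COc1ccc(C(=O)NN(C(=O)c2ccccc2Cl)C(C)(C)C)cc1` — 51.3 nM
compound 2 `CC(C)(C)N(NC(=O)c1cccc(Cl)c1Cl)C(=O)c1ccccc1Cl` — 9.33 nM

Compound 2 gives the lowest number of the two measured. Among the compounds with values here, the only measured step is a 5.5-fold lower number from compound 1 to compound 2 (0.74 log units; beyond the scatter), which exchanges one aryl group on the carbonyl carbon for another aryl group and is beyond the scatter.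

Compound 3 `CCCCCCC(=O)NN(C(=O)c1ccccc1Cl)C(C)(C)C` is not yet measured in this assay. Its difference from compound 2 is hexyl in place of 2,3-dichlorophenyl on a carbonyl carbon. Here the aromatic ring at that carbonyl carbon is given up altogether for a hexyl chain, so the step from compound 1 to compound 2 bears on it only in showing that this carbonyl position is sensitive to what is attached there; it does not show how an open chain behaves in place of a ring. Within the data shown here, no measured pair covers a ring-to-chain exchange.

With a change of this kind at a position already shown to matter, a step to a higher number is expected, of moderate to large size: a 16-fold higher number from compound 2 to compound 3 (1.21 log units; beyond the scatter). Compound 3 is therefore estimated at 150 nM, with a range from 30 nM to 1000 nM.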

Compound 3, half-maximal effective concentration: 741 nM
Compound 3: the middle estimate sits 4.9-fold (0.69 log units) below what was measured; the range from low to high includes it.
By their numbers in this assay, from the lowest: compound 2; then compound 1; then compound 3.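

Notes on the carbonyl carbon that varies across the series: the earlier pair compared only one aryl group with another, whereas in this assay the first exchange of a ring for an open chain gives a large step when hexyl replaces 2,3-dichlorophenyl (a 79-fold higher number from compound 2 to compound 3 (1.90 log units; beyond the scatter)). Read against the other aryl group, the same kind of exchange also gives a large step when hexyl replaces 4-methoxyphenyl (a 14-fold higher number from compound 1 to compound 3 (1.16 log units; beyond the scatter)), so among the three compounds shown, both aryl groups give lower numbers than hexyl, and neither step lies within the scatter. Nothing available explains why the open chain gives the higher number.

Since hexyl differs from both aryl groups in more than the loss of the ring, these steps do not separate the effect of the aromatic ring from that of its substituents, and a cyclohexyl ring, an unsubstituted phenyl ring, a butyl chain or an octyl chain at this carbonyl carbon would be needed to do so. From the compounds shown here alone, whether the size of these steps holds with a group other than the 2-chlorophenyl and tert-butyl groups shared by all three compounds also stays open.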